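The source may report more compounds than this note shows. Statements on the series, on what has been measured and on what is new or still open speak of the compounds shown alone.

Going by the values given here, compound 2 `CC(C)c1cc2c3c(c1OC(=O)CCl)OC(=O)[C@@]31CCCC(C)(C)[C@@H]1CC2` gives 103000 nM in an ADME assay on AGS cells (Homo sapiens) for cytotoxicity, read by neutral red uptake, with a stated time of 24 h (on this read-out lower numbers stand for stronger inhibition and higher numbers for weaker inhibition), the lowest of the three numbers so far; compound 1 `CC(=O)Oc1c(C(C)C)cc2c3c1OC(=O)[C@@]31CCCC(C)(C)[C@@H]1CC2` gives 275000 nM and compound 3 `CCCCCCCCCCCC(=O)Oc1c(C(C)C)cc2c3c1OC(=O)[C@@]31CCCC(C)(C)[C@@H]1CC2` gives 413000 nM. Compound 4 `CC(C)c1cc2c3c(c1OC(=O)c1cccnc1)OC(=O)[C@@]31CCCC(C)(C)[C@@H]1CC2` differs from compound 2 by pyridin-3-yl in place of chloromethyl on a carbonyl carbon. Among the compounds with values here, two measured steps concern the same carbonyl substituent: a 2.7-fold lower number from compound 1 to compound 2 (0.43 log units; beyond the scatter), and a 4.0-fold higher number from compound 2 to compound 3 (0.60 log units; beyond the scatter). Both point the same way: the chloro sits on the lowest number, and exchanging it raises the number modestly. Pyridin-3-yl is not decyl, but the chloromethyl leaves here too, so a modest rise is expected, about a 2.4-fold higher number from compound 2 to compound 4 (0.39 log units; beyond the scatter). Compound 4 is accordingly estimated at 250000 nM, within a range of 100000 nM to 600000 nM.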

Compound 4, half-maximal inhibitory concentration: 280000 nM
Estimate against measurement, compound 4: 1.1-fold (0.05 log units) below, and the stated range covers the measured number.
By their numbers in this assay, from the lowest: compound 2; then compounds 1, 4 and 3 (each within the scatter of the next).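

In this assay, an aromatic ring on this carbonyl carbon gives a 2.7-fold higher number from compound 2 to compound 4 (0.43 log units; beyond the scatter), while a 1.0-fold higher number from compound 1 to compound 4 (0.01 log units; within the scatter) and a 1.5-fold lower number from compound 3 to compound 4 (0.17 log units; within the scatter) both stay within the scatter. Of the four groups on this carbonyl carbon, only chloromethyl now stands apart, and methyl, undecyl and pyridin-3-yl do not separate from one another. No evidence on the cause accompanies these numbers.

Going by these compounds, it remains open whether the lower number of compound 2 belongs to the chlorine or to the whole chloromethyl group. Bromomethyl or an aminomethyl group on the same carbonyl carbon would bear on this.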